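The source may hold more compounds than are shown below. What is called first, only, known or untested is meant among the compounds shown, and "the series" means these compounds.

Measured so far in a functional assay on A549 cells (Homo sapiens) for antiproliferative activity, read by MTT assay, with a stated time of 24 h; a higher number here means a weaker inhibitor, a lower number a stronger inhibitor:
- compound 1 `CCCCOc1ccc(C(=O)NNC(=O)c2cccc(NS(=O)(=O)c3cnc(O)nc3O)c2)cc1`: 7760 nM
- compound 2 `Cc1ccccc1C(=O)NNC(=O)c1cccc(NS(=O)(=O)c2cnc(O)nc2O)c1`: 8010 nM
- compound 3 `CCCCOc1ccc(C(=O)NNC(=O)c2ccccc2NS(=O)(=O)c2cnc(O)nc2O)cc1`: 4960 nM

Compound 2 differs from compound 1 only by 2-methylphenyl in place of 4-butoxyphenyl on a carbonyl carbon, and that change gave a 1.0-fold higher number from compound 1 to compound 2 (0.01 log units; within the scatter). Compound 1 and compound 3 contain the same atoms joined differently; the difference between the two cores is not broken down here.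

Compound 4 `Cc1ccccc1C(=O)NNC(=O)c1ccccc1NS(=O)(=O)c1cnc(O)nc1O` is not yet measured. It carries the change (2-methylphenyl in place of 4-butoxyphenyl on a carbonyl carbon), the same change as from compound 1 to compound 2, at the same kind of place. Since that change left the number essentially unmoved between compound 1 and compound 2, the expected step is a 1.0-fold higher number from compound 3 to compound 4 (0.01 log units; within the scatter), a step of similar size to the earlier one. Compound 4 is therefore estimated at 5100 nM in this assay, with a likely range from 2500 nM to 10500 nM.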

Compound 4, half-maximal inhibitory concentration: 5450 nM
Compound 4: the middle estimate sits 1.1-fold (0.03 log units) below what was measured, and the stated range covers the measured number.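

In this assay, putting 2-methylphenyl in place of 4-butoxyphenyl on the carbonyl carbon again gave no step beyond the scatter, with a 1.1-fold higher number from compound 3 to compound 4 (0.04 log units; within the scatter). Set side by side, the two steps agree: the same change on two cores in this assay, a 1.0-fold higher number (0.01 log units; within the scatter) from compound 1 to compound 2 and a 1.1-fold higher number (0.04 log units; within the scatter) from compound 3 to compound 4, 1.1-fold (0.03 log units) apart, within the scatter of two such steps. This shows that the change behaved alike on these two cores, but both steps are flat, so the match does not show that a change with a real effect would carry over, nor why neither step rose above the scatter.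

The compounds shown leave open whether a phenyl ring carrying an amine or a carboxylic acid would move the number at this place. They also leave open how the change would behave on any other core.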